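The compounds below may be only part of what the source reports. "The series", "measured", "known", "first", "only" and "open" are said of these compounds alone.

Working notes on the series in a functional assay on NCI-H460 cells (Homo sapiens) for inhibition, read by MTT assay, with a stated time of 24 h, tested at 0.1 ug/mL; a lower number here means less inhibition of growth, a higher number more inhibition of growth at the concentration tested. Compound 1 (`O=C(CCCCC(S)CCS)NO`) gives 5.7%, within the scatter of both compound 2 (`O=C(CCCCC1CCSS1)Nc1ccc(Cl)cn1`) at 3.93% and compound 3 (`O=C(CCCCC1CCSS1)Nc1ccc(Br)cn1`) at 9%. Compound 4 (`O=C(CCCCC(S)CCS)Nc1ccccc1`) is still unmeasured. Its difference from compound 1 is phenyl in place of hydroxy on an amide-type nitrogen. Among the measured compounds shown here, the one measured step, a number 5.1 percentage points higher from compound 2 to compound 3 (within the scatter), comes with bromo in place of chloro on an aromatic carbon, so it bears on this change only indirectly. Those two compounds also carry an aromatic ring on an amide-type nitrogen, and their values match compound 1 within the scatter, though they differ from it elsewhere too. No step beyond the scatter is therefore expected in this assay. The expected step, a number 1.3 percentage points higher from compound 1 to compound 4 (within the scatter), is small. For compound 4 the estimated value is 7%, with an expected range from 1% to 18%.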

Compound 4, percent growth inhibition at one concentration: 5.5%
For compound 4 the middle estimate is 1.5 percentage points above the measured one; the range from low to high includes it.
By their numbers in this assay, from the lowest: compounds 2, 4, 1 and 3 (each within the scatter of the next).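

In this assay, among the compounds shown here, phenyl in place of hydroxy on an amide-type nitrogen gives a number 0.2 percentage points lower from compound 1 to compound 4 (within the scatter), the first direct reading of this change at this position. Replacing one heavy atom with six, including an aromatic ring, thus produces no step beyond the scatter at this concentration. No supporting measurement bears on this result.

Going by these compounds, whether a longer alkyl chain or an amine on this nitrogen would behave the same remains open. Also open, on these data alone, is whether compound 1 and compound 4 stay alike at higher concentrations.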